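Phenyl in place of tert-butyl on compound 3

The compounds below may be only part of what the source reports. "The series", "measured", "known", "first", "only" and "open" are said of these compounds alone.

Of the compounds shown here, three sharing one core have been measured in a functional assay on CHO-K1 cells for antagonist activity at transient receptor potential cation channel subfamily V member 1 (Homo sapiens), read by FLIPR; a lower number here means a stronger inhibitor, a higher number a weaker inhibitor. Compound 1 `Cc1ccc(Nc2nc(C(F)(F)F)ccc2CNC(=O)C(C)c2ccc(NS(C)(=O)=O)c(F)c2)cc1C` gives 39.3 nM. Going by the values given here, compound 2 `CC(C(=O)NCc1ccc(C(F)(F)F)nc1N1CCC(=O)CC1)c1ccc(NS(C)(=O)=O)c(F)c1` gives 91 nM; the only one-place step among the measured compounds is a 2.3-fold higher number from compound 1 to compound 2 (0.36 log units; beyond the scatter). Compound 3 `CC(C(=O)NCc1ccc(C(F)(F)F)nc1N1CCC2(CC1)CC(C(C)(C)C)=NO2)c1ccc(NS(C)(=O)=O)c(F)c1` gives 3.8 nM, the lowest of the three numbers, below the number of compound 1 and further below that of compound 2, both gaps beyond the scatter, so compound 3 is the strongest inhibitor measured here.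

Compound 4 `CC(C(=O)NCc1ccc(C(F)(F)F)nc1N1CCC2(CC1)CC(c1ccccc1)=NO2)c1ccc(NS(C)(=O)=O)c(F)c1` differs from compound 3 in one place: phenyl in place of tert-butyl on a carbon with a double bond to nitrogen. Among the compounds with values here, none of the measured steps bears on this position; the single step that was measured changes a different part of the molecule, so it gives no guidance on how a phenyl instead of a tert-butyl at this carbon will read out. Compound 3 already gives a small number, so the expected step of a 1.3-fold higher number from compound 3 to compound 4 (0.12 log units; within the scatter) is taken as none beyond the scatter, with the wider uncertainty reflected in the range. Compound 4 is therefore expected to give about 5 nM in this assay, within a range from 1.5 nM to 20 nM.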

Compound 4, inhibition constant: 6.1 nM
Compound 4: the middle estimate sits 1.2-fold (0.09 log units) below what was measured, within the range that was stated.
By their numbers in this assay, from the lowest: compounds 3 and 4 (each within the scatter of the next); then compound 1; then compound 2.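

In this assay, phenyl in place of tert-butyl on the carbon with a double bond to nitrogen gives a 1.6-fold higher number from compound 3 to compound 4 (0.21 log units; within the scatter), so the two groups cannot be told apart in this read-out. Going by these compounds alone, this is the first view of this position, and it shows that a group with no ring and a six-membered aromatic ring of carbon only can stand on this carbon without a difference beyond the scatter, at least for this pair. Nothing available here accounts for why these two different groups read out alike.

Both groups consist of carbon and hydrogen alone, with no hydrogen-bond donors or acceptors and no net charge, so the compounds shown leave open how this position would respond to a group such as a carboxylic acid or an amine. Also open, as far as these compounds go, is whether the same flat picture would hold for a much smaller group such as methyl, for a longer chain such as n-hexyl, or for a phenyl that itself carries a methoxy group.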